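Aryl variation at the shared core: acetylphenyl to trifluoromethylphenyl

The source may report more compounds than this note shows. Statements on the series, on what has been measured and on what is new or still open speak of the compounds shown alone.

Three compounds on the shared core have numbers in a functional assay on CCRF-CEM cells (Homo sapiens) for inhibition, read by sulforhodamine B assay, with a stated time of 48 h, tested at 10 uM; a higher number here means more inhibition at the concentration tested (going by the name of the read-out), a lower number less inhibition. Compound 1 `COc1ccc(-c2cn3ccnc3c(-c3ccc4ncn(C5CCCCC5)c4c3)n2)cc1` carries 4-methoxyphenyl and in this assay gives 93.3%. Compound 2 `c1ccc2c(-c3cn4ccnc4c(-c4ccc5ncn(C6CCCCC6)c5c4)n3)cccc2c1` carries naphthalen-1-yl and gives 17.5%. Compound 3 `CC(=O)c1ccc(-c2cn3ccnc3c(-c3ccc4ncn(C5CCCCC5)c4c3)n2)cc1` carries 4-acetylphenyl and gives 1.1%, the lowest of the three; compound 2 is nearest, and compound 1 furthest. The steps are a number 92.2 percentage points lower from compound 1 to compound 3 (beyond the scatter) and a number 16.4 percentage points lower from compound 2 to compound 3 (beyond the scatter), both beyond the scatter, and a number 75.8 percentage points lower from compound 1 to compound 2 (beyond the scatter).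

Compound 4 `FC(F)(F)c1cccc(-c2cn3ccnc3c(-c3ccc4ncn(C5CCCCC5)c4c3)n2)c1` differs from compound 3 as follows: 3-(trifluoromethyl)phenyl in place of 4-acetylphenyl on an aromatic carbon. Going by the values given here, no measured step concerns trifluoromethyl, so only indirect bearing exists: the removal of acetyl is what both measured steps into compound 3 share, and both went down into compound 3, the first large and the second modest. Leaving compound 3 by swapping 4-acetylphenyl out is therefore expected to move upward, though how far the new group reaches toward the number of compound 1 cannot be told from compound 2 alone, which stayed low without a carbonyl. The expected step is a number 18.9 percentage points higher from compound 3 to compound 4 (beyond the scatter). In this assay compound 4 is estimated at 20%, within 0% to 60%.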

Compound 4, a percentage reported as inhibition, at one concentration (the size of the read-out at that concentration, not a potency): 27.3%
The estimate for compound 4 lay 7.3 percentage points below the measured number; low and high end bracket the measured number.
By their numbers in this assay, from the lowest: compound 3; then compounds 2 and 4 (each within the scatter of the next); then compound 1.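

In this assay, replacing 4-acetylphenyl with 3-(trifluoromethyl)phenyl, a group with no hydrogen-bond acceptor, lifts the number off the bottom of the series (a number 26.2 percentage points higher from compound 3 to compound 4 (beyond the scatter)), so this position does not hold every aryl replacement of compound 3 at the level of 4-acetylphenyl. The gain is limited, however: 3-(trifluoromethyl)phenyl falls well short of 4-methoxyphenyl (a number 66 percentage points lower from compound 1 to compound 4 (beyond the scatter)) and cannot be told apart from naphthalen-1-yl (a number 9.8 percentage points higher from compound 2 to compound 4 (within the scatter)), leaving 4-methoxyphenyl alone at the high end among these four aryl groups. No measurement shown here explains these differences.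

The step from 4-methoxyphenyl to 3-(trifluoromethyl)phenyl changes both the substituent and its place on the phenyl ring, so the compounds shown cannot separate the contribution of one from the other. Going by these compounds, it also remains open whether the high number of compound 1 is specific to methoxy or extends to related groups on the phenyl ring, such as hydroxyl, ethoxy or dimethylamino.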